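The source may hold more compounds than are shown below. What is called first, only, known or untested is meant among the compounds shown, and "the series" means these compounds.

Compound 1 `COc1ncnc2c1c(-c1ccoc1)cn2[C@@H]1O[C@H](CO)[C@@H](O)[C@H]1O` is the starting point. Going by the values given here, in a functional assay on HCT-116 cells (Homo sapiens), read by MTT assay, with a stated time of 72 h (a higher number here means a weaker inhibitor, a lower number a stronger inhibitor), compound 1 gives 130 nM, the only true number among the three measured compounds. Compound 2 `Cc1ncnc2c1c(-c1ccoc1)cn2[C@@H]1O[C@H](CO)[C@@H](O)[C@H]1O`, with methyl in place of methoxy on an aromatic carbon, reaches only a limit of the assay, > 20000 nM. Compound 3 `COc1nc(N)nc2c1c(-c1ccoc1)cn2[C@@H]1O[C@H](CO)[C@@H](O)[C@H]1O`, with amino in place of hydrogen on an aromatic carbon, also stops at a limit, > 20000 nM. Both steps, an at least 150-fold higher number from compound 1 to compound 2 (2.18 log units; beyond the scatter) and an at least 150-fold higher number from compound 1 to compound 3 (2.18 log units; beyond the scatter), are large losses, so compound 1 stands alone as the active member shown (the limit of > 20000 nM in this assay, at which 2 of the 3 values shown sit). Compound 4 `COc1ncnc2c1c(-c1cc3ccccc3o1)cn2[C@@H]1O[C@H](CO)[C@@H](O)[C@H]1O` alters a different part of the molecule: 1-benzofuran-2-yl in place of furan-3-yl on an aromatic carbon. Neither measured step touches that group, so they offer no direct guide; they only show that the two other changes tried on the shared core were both costly. Compound 4 is therefore expected to give about 1500 nM, somewhere between 100 nM and 20000 nM. That would be an expected step of a 12-fold higher number from compound 1 to compound 4 (1.06 log units; beyond the scatter), a cautious guess toward weaker inhibition.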

Compound 4, half-maximal inhibitory concentration: 14500 nM
Beside the measured number, compound 4's estimate is 9.7-fold (0.99 log units) below it; the measured number falls inside the stated range.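

At this position on the five-membered aromatic ring, the group matters as well: 1-benzofuran-2-yl in place of furan-3-yl gives a 110-fold higher number from compound 1 to compound 4 (2.05 log units; beyond the scatter). So a large loss is now seen here too, not only at the two other places changed on the shared core. Still, compound 4 gives a true number, whereas compound 2 and compound 3 stop at a limit of the assay: the limit of > 20000 nM in this assay, at which 2 of the 4 values shown sit.

The compounds shown leave open whether a plain phenyl or a thiophen-3-yl group on this carbon would keep the activity of compound 1. They also do not tell what lies behind the loss.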